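The compounds below may be only part of what the source reports. "The series", "measured", "known", "first", "only" and "open" are said of these compounds alone.

Of the compounds shown here, three sharing one core have been measured. Compound 1 `COc1cc(Cl)cc(-c2nn(-c3cccc(NC(=O)Nc4ccc(Cl)c(C(F)(F)F)c4)c3)cc2-c2ccncc2)c1`, compound 2 `COc1cc(Cl)cc(-c2nn(-c3cccc(NC(=O)Nc4cc(C(F)(F)F)cc(C(F)(F)F)c4)c3)cc2-c2ccncc2)c1` and compound 3 `COc1cc(Cl)cc(-c2nn(-c3cccc(NC(=O)Nc4ccc(Cl)c(Cl)c4)c3)cc2-c2ccncc2)c1` were tested in a functional assay on NCI-H322M cells (Homo sapiens) for inhibition, read by sulforhodamine B assay, with a stated time of 48 h, tested at 10 uM; a higher number here means a weaker effect of the compound at the concentration tested, a lower number a stronger effect; in that assay compound 1 gives 18.7%, compound 2 gives 11% and compound 3 gives 32.3%. Compound 3 therefore shows the highest number of the three, and so the weakest effect at the tested concentration: compound 1 sits nearest to it and compound 2 furthest, both gaps lying beyond the usual scatter. Compound 4 `COc1cc(Cl)cc(-c2nn(-c3cccc(NC(=O)Nc4cccc(C(F)(F)F)c4)c3)cc2-c2ccncc2)c1` has not yet been measured. It differs from compound 3 in one place: 3-(trifluoromethyl)phenyl in place of 3,4-dichlorophenyl on an amide-type nitrogen. One measured step speaks to this change. Putting chloro where a trifluoromethyl group had been gave a number 13.6 percentage points higher from compound 1 to compound 3 (beyond the scatter), a modest rise beyond the scatter. Compound 4 goes the other way, bringing a trifluoromethyl group back, yet it also loses a chlorine that compound 1 and compound 3 both carry, so the earlier step cannot be applied exactly. A drop in this assay is expected for compound 4, estimated at a number 10.3 percentage points lower from compound 3 to compound 4 (beyond the scatter). For compound 4 the expected value in this assay is 22%, with a likely range from 10% to 38%.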

Compound 4, a percentage reported as activity, at one concentration (the size of the read-out at that concentration, not a potency): 26.2%
The estimate for compound 4 lay 4.2 percentage points below the measured number, and the stated range covers the measured number.
By their numbers in this assay, from the lowest: compounds 2, 1, 4 and 3 (each within the scatter of the next, the first and the last beyond it).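

In this assay, the exchange of 3,4-dichlorophenyl for 3-(trifluoromethyl)phenyl on the amide-type nitrogen gives a number 6.1 percentage points lower from compound 3 to compound 4 (within the scatter), so these two groups cannot be told apart here, even though they differ in their atoms and in heavy-atom count. Going by these compounds alone, compound 4 also allows each group on the compound 1 and compound 2 aromatic rings to be examined singly: hydrogen in place of chloro gives a number 7.5 percentage points higher from compound 1 to compound 4 (within the scatter), which leaves no measurable contribution from that chlorine, while hydrogen in place of one trifluoromethyl gives a number 15.2 percentage points higher from compound 2 to compound 4 (beyond the scatter), the only new step that clears the scatter. Among these four compounds, then, the one single-group removal that is clearly visible is the loss of a trifluoromethyl group from compound 2, a weakening of the effect at the tested concentration, though this rests on one pair alone.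

The compounds shown leave open whether a methoxy group, a nitrile or a single fluorine in place of the trifluoromethyl group of compound 4 would read the same way, and how a phenyl ring carrying no group at all would compare. No measurement here accounts for why the steps differ in size.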